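The compounds below may be only part of what the source reports. "The series", "measured", "known", "first", "only" and "open" are said of these compounds alone.

In a functional assay on A549 cells (Homo sapiens) for inhibition, read by MTT assay, with a stated time of 48 h (on this read-out lower numbers stand for stronger inhibition and higher numbers for weaker inhibition), compound 1 `O=C1N/C(=N\Cc2ccc(C(F)(F)F)cc2)S/C1=C1/CCNC(=O)c2[nH]ccc21` gives > 100000 nM, which is a limit of the assay and not a number. Compound 2 `O=C1N/C(=N\Cc2ccccc2Cl)S/C1=C1/CCNC(=O)c2[nH]ccc21` gives > 100000 nM, which is also a limit. Compound 1 therefore stands at the edge of what this assay can report, and no exact potency is known for either compound. Compound 3 `Cc1ccc(C/N=C2\NC(=O)/C(=C3\CCNC(=O)c4[nH]ccc43)S2)cc1` keeps the core of compound 1 and changes one group: methyl in place of trifluoromethyl on an aromatic carbon. Among the measured compounds shown here, no measured pair shows what this swap does. For the measured compounds named here, the only guide is the limit of > 100000 nM in this assay, at which 2 of the 2 values shown sit, so no shift beyond the usual scatter is expected. The estimated step is a number no higher from compound 1 to compound 3 (the limit leaves the size open), with no firm direction. Compound 3 is expected near 100000 nM, with an estimated range from 40000 nM to 250000 nM, and it will probably be reported only as a limit.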

Compound 3, half-maximal inhibitory concentration: 9080 nM
The estimate for compound 3 lay 11-fold (1.04 log units) above the measured number, and the stated range ends above it.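

On the aromatic carbon para to a large group, the choice of group clearly matters: in this assay, methyl in place of trifluoromethyl brings an at least 11-fold lower number from compound 1 to compound 3 (1.04 log units; beyond the scatter). Changing 2-chlorophenyl to 4-methylphenyl brings an at least 11-fold lower number from compound 2 to compound 3 (1.04 log units; beyond the scatter), so compound 3 shows that the shared core can give a measurable number in this assay, which the two limits could not show. The second step changes more than the group on one carbon, and neither step explains why methyl differs from trifluoromethyl.

As far as these compounds go, whether an amine, a methoxy group or a carboxylic acid on this carbon would lower the number further remains open. The true size of both steps also remains open, since each starts from a limit and not a number: the limit of > 100000 nM in this assay, at which 2 of the 3 values shown sit.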